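The source may report more compounds than this note shows. Statements on the series, on what has been measured and on what is new or still open speak of the compounds shown alone.

Three measured compounds share one core and differ only in the second aryl ring of the urea. Compound 1 has the structure `COc1ccc(NC(=O)Nc2cc(C)nc3ccccc23)cc1F` and is the only one with a numerical result: in an ADME assay on BJ cells (Homo sapiens) for cytotoxicity, with a stated time of 72 h (a higher number here means that more compound is needed for the effect, a lower number that less compound is needed), compound 1 gives 26000 nM as its value. Compound 2 has the structure `Cc1cc(NC(=O)Nc2ccccc2C(F)(F)F)c2ccccc2n1` and reaches only a limit of the assay, where in this assay compound 2 gives > 25000 nM as that limit. Compound 3 has the structure `Cc1cc(NC(=O)Nc2ccccc2OC(F)(F)F)c2ccccc2n1` and likewise reaches only a limit, where in this assay compound 3 gives > 25000 nM as that limit. Compound 3 thus stands at the limit of > 25000 nM in this assay, at which 2 of the 3 values shown sit, together with compound 2, and the step that the two limits leave unreadable from compound 2 to compound 3 has no readable size because the limit of > 25000 nM in this assay, at which 2 of the 3 values shown sit, caps both values.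

Compound 4 has the structure `Cc1cc(NC(=O)Nc2ccccc2C(C)(C)C)c2ccccc2n1` and differs from compound 3 in one place: tert-butyl in place of trifluoromethoxy on an aromatic carbon on the ring. Within the data shown here, the only measured step at this position is a step that the two limits leave unreadable from compound 2 to compound 3 and it left compound 3 at the limit, so no step on a tert-butyl group exists to guide the expectation. The expectation is that in this assay compound 4 also sits near the limit, with an expected step that the limit leaves unreadable from compound 3 to compound 4 inside the scatter. The estimate for compound 4 is 30000 nM within a range from 12000 nM to 80000 nM in this assay.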

Compound 4, half-maximal effective concentration: 22000 nM
Compound 4: middle estimate off by 1.4-fold (0.13 log units), on the high side, and the stated range covers the measured number.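

Compound 4 gives this position its first numerical result in this assay and so turns the swap of the ortho group into something with a floor: tert-butyl in place of trifluoromethoxy gives an at least 1.1-fold lower number from compound 3 to compound 4 (0.05 log units; that floor lies within the scatter) and tert-butyl in place of trifluoromethyl gives an at least 1.1-fold lower number from compound 2 to compound 4 (0.05 log units; that floor lies within the scatter) whereas the earlier step between the two fluorinated groups could not be read. Among these compounds, both floors lie within the scatter, so neither step establishes a real difference, and what is new is only that a group with no fluorine at this position returns a number and not a limit. How far each step really reaches stays unread because the two fluorinated compounds rest on a limit: the limit of > 25000 nM in this assay, at which 2 of the 4 values shown sit.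

The compounds shown leave open the true size of these steps and whether any group at this position moves the number beyond the scatter. They also leave open what an amine, a carboxylic acid or a longer chain in the place of tert-butyl would give in this assay on the same shared core.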